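A few compounds are considered here, and "the series" means these few. Any claim that something is new, unique, unknown or untested is made for them only; others in the source may bear on it.

Compound 1 `COc1cc(NC2CCCC2)n2nc(-c3ccc(F)cc3)c(-c3ccnc(NC4CCCC4)n3)c2c1` gives > 40000 nM in an ADME assay on Vero cells (Chlorocebus sabaeus) for cytotoxicity; on this read-out lower numbers stand for higher toxicity in this test and higher numbers for lower toxicity in this test.
Compound 2 `CC(C)Oc1cc(NC2CCCC2)n2nc(-c3ccc(F)cc3)c(-c3ccnc(NC4CCCC4)n3)c2c1` gives > 40000 nM in this assay.

The value of compound 1 is a limit of this assay, not a number. The value of compound 2 is likewise a limit. The step that the two limits leave unreadable from compound 1 to compound 2 therefore cannot be sized; compound 2 stands at the limit of > 40000 nM in this assay, at which 2 of the 2 values shown sit. Compound 3 `Fc1ccc(-c2nn3c(NC4CCCC4)cc(OCC4CC4)cc3c2-c2ccnc(NC3CCCC3)n2)cc1` differs from compound 2 by cyclopropylmethyl in place of isopropyl on an oxygen on an aromatic ring. No readable step bears on this change, so in this assay no shift beyond the scatter is expected, a step that the limit leaves unreadable from compound 2 to compound 3. Compound 3 is estimated at 60000 nM, within 30000 nM to 200000 nM.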

Compound 3, half-maximal cytotoxic concentration: > 40000 nM
Compound 3: a limit, no number (the forecaster's own chance of this, stated with the estimate: 80%); the middle value lies beyond the limit too.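

Among the compounds shown here, compound 1, compound 2 and compound 3 all sit at the same limit in this assay, so no step among them can be read. From the compounds shown here alone, how far each compound lies beyond that limit, and whether the group on the oxygen matters here, stays open.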